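Methylsulfanyl in place of methoxy on the shared core

The compounds below may be only part of what the source reports. "The series", "measured", "known", "first", "only" and "open" are said of these compounds alone.

Values in a functional assay on MT4 cells (Homo sapiens) for inhibition (a higher number here means a weaker inhibitor, a lower number a stronger inhibitor), each one a limit of the assay:
compound 1 `C=C1[C@@H](O)[C@H](n2cnc3c(Cl)nc(N)nc32)O[C@@H]1CO`: > 500000 nM
compound 2 `C=C1[C@@H](O)[C@H](n2cnc3c(N)nc(N)nc32)O[C@@H]1CO`: > 200000 nM
compound 3 `C=C1[C@@H](O)[C@H](n2cnc3c(OC)nc(N)nc32)O[C@@H]1CO`: > 500000 nM

Compound 3 stands at > 500000 nM, which is a limit and not a number. Among the measured compounds shown here, the whole series sits at limits, the limit of > 500000 nM in this assay, at which 2 of the 3 values shown sit, and (the limit of > 200000 nM in this assay, at which 1 of the 3 values shown sits), so no measured compound offers a readable value.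

Compound 4 `C=C1[C@@H](O)[C@H](n2cnc3c(SC)nc(N)nc32)O[C@@H]1CO` has not been measured and differs from compound 3 by one change: methylsulfanyl in place of methoxy on an aromatic carbon. In words, this is methylsulfanyl in place of methoxy on an aromatic carbon.

The measured steps that bear on it are the other replacements on an aromatic carbon: a step that the two limits leave unreadable from compound 1 to compound 3, a step that the two limits leave unreadable from compound 2 to compound 3 and a step that the two limits leave unreadable from compound 1 to compound 2. None of them has a size that can be read, so they set no scale for the new replacement. Chloro, amino and methoxy each leave their compound at a limit in this assay, and no compound in the series goes against this.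

Starting from compound 3 at > 500000 nM, a limit, no step beyond the scatter is expected, and a further limit is the likely report. The estimated step is a number no higher from compound 3 to compound 4 (the limit leaves the size open). For compound 4 the estimated value is 500000 nM, with an expected range from 200000 nM to 900000 nM.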

Compound 4, half-maximal inhibitory concentration: > 500000 nM
Compound 4: only a limit was reported; the forecaster's own chance of this, stated with the estimate: 90%; the middle value sits exactly at the limit.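

In this assay compound 4 gives > 500000 nM, a limit of the assay. With compound 1, compound 2, compound 3 and compound 4 all at limits, none of the steps to compound 4 can be read. The compounds shown leave open whether chloro, amino, methoxy and methylsulfanyl differ at all in this assay.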